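Demethylation of a dimethoxyphenyl pyrazoline: expected cytotoxicity

The source may report more compounds than this note shows. Statements on the series, on what has been measured and on what is new or still open speak of the compounds shown alone.

Measured compounds:
compound 1 `COc1ccc(C2CC(c3cc(OC)c(OC)c(OC)c3)=NN2)cc1OC` gives 44000 nM in a functional assay on B16 cells (Mus musculus) for cytotoxicity, read by MTT assay, with a stated time of 72 h; on this read-out lower numbers stand for stronger inhibition and higher numbers for weaker inhibition;
compound 2 `COc1cc(C2=NNC(c3cc(OC)c(OC)c(OC)c3)C2)cc(OC)c1OC` gives 56000 nM in this assay.

Compound 1 stands at the lowest of the two numbers recorded so far, with compound 2 nearest to it: a 1.3-fold higher number from compound 1 to compound 2 (0.10 log units; within the scatter). Compound 3 `COc1ccc(C2CC(c3cc(OC)c(OC)c(OC)c3)=NN2)cc1O` differs from compound 1 by hydrogen in place of methyl on an oxygen on an aromatic ring. Going by the values given here, no measured step bears on this kind of change; the only step recorded, from compound 1 to compound 2, is of another kind and stays within the scatter. The account therefore expects no step beyond the scatter in this assay, a 1.0-fold lower number from compound 1 to compound 3 (0.02 log units; within the scatter). Compound 3 is estimated at 42000 nM, in a range from 15000 nM to 120000 nM.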

Compound 3, half-maximal inhibitory concentration: 2100 nM
Beside the measured number, compound 3's estimate is 20-fold (1.30 log units) above it, outside the stated range (below it).
By their numbers in this assay, from the lowest: compound 3; then compounds 1 and 2 (each within the scatter of the next).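

Going from methoxy to hydroxy on this aromatic ring gives, in this assay, a 21-fold lower number from compound 1 to compound 3 (1.32 log units; beyond the scatter). Going by these compounds alone, the earlier compounds showed only a step within the scatter, a 1.3-fold higher number from compound 1 to compound 2 (0.10 log units; within the scatter), and that step was a different change, so this is the first sign that the core of compound 1 responds strongly to a change at this oxygen. Nothing shown here accounts for the size of this step.

The compounds shown leave open whether the free hydroxy itself is what matters. An amine in its place, or an ethoxy group, would help to test that.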